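Cytotoxicity of a biaryl carbinol series: substituent at the distal ring

This account rests on a few compounds, and the source may have more. Where it says the series, first, only, none or still open, it means among the compounds named here.

Compound 1 `COc1cc(CC(O)c2ccc(-c3ccc(CO)cc3)cc2)c([N+](=O)[O-])cc1OC`; in an ADME assay on HeLa Rh cells (Homo sapiens) for cytotoxicity, read by microscopy (a lower number here means that less compound is tolerated, a higher number that more compound is tolerated), compound 1 gives > 244000 nM, a limit of the assay and not a number.
Compound 2 `COc1cc(CC(O)c2ccc(-c3ccc(F)cc3)cc2)c([N+](=O)[O-])cc1OC`; in this assay compound 2 gives 4500 nM.
Compound 3 `COc1cc(CC(O)c2ccc(-c3cccc(C#N)c3)cc2)c([N+](=O)[O-])cc1OC`; in this assay compound 3 gives 5200 nM.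

Compound 1 stands apart from the other two, sitting at the limit (the limit of > 244000 nM in this assay, at which 1 of the 3 values shown sits), so its true value is known only as a range. The two measured steps both leave compound 1 and both run far beyond the scatter: an at least 54-fold lower number from compound 1 to compound 2 (1.73 log units; beyond the scatter) and an at least 46-fold lower number from compound 1 to compound 3 (1.67 log units; beyond the scatter). Between compound 2 and compound 3 the change is a 1.2-fold higher number from compound 2 to compound 3 (0.06 log units; within the scatter), so the two substituted analogues are indistinguishable here.

Compound 4 `COc1cc(CC(O)c2ccc(-c3cccc([N+](=O)[O-])c3)cc2)c([N+](=O)[O-])cc1OC` has not yet been measured in this assay. It differs from compound 1 by 3-nitrophenyl in place of 4-(hydroxymethyl)phenyl on an aromatic carbon. The step from compound 1 to compound 3 is the closest parallel, since there too a 3-substituted phenyl replaced the 4-(hydroxymethyl)phenyl and the number fell sharply. An analogous large drop in this assay is therefore expected for compound 4, as a step of an at least 48-fold lower number from compound 1 to compound 4 (1.68 log units; beyond the scatter). The estimate for compound 4 is 5000 nM, with a range from 1500 nM to 20000 nM.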

Compound 4, half-maximal cytotoxic concentration: 5500 nM
Compound 4: the middle estimate sits 1.1-fold (0.04 log units) below what was measured; low and high end bracket the measured number.
By their numbers in this assay, from the lowest: compounds 2, 3 and 4 (each within the scatter of the next). At a limit, above all of these: compound 1.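

With 3-nitrophenyl on this aromatic carbon, a third replacement of the 4-(hydroxymethyl)phenyl group gives a large step in this assay: an at least 44-fold lower number from compound 1 to compound 4 (1.64 log units; beyond the scatter). Nitro in place of cyano on an aromatic carbon gives no difference that can be told apart (a 1.1-fold higher number from compound 3 to compound 4 (0.02 log units; within the scatter)), and the same holds for 3-nitrophenyl in place of 4-fluorophenyl (a 1.2-fold higher number from compound 2 to compound 4 (0.09 log units; within the scatter)), so compounds 2, 3 and 4 now form a group of three within the scatter despite their different substituents. Compound 1 alone stands apart, and its value is a limit and not a number, so every step from it gives only a bound on the true size: the limit of > 244000 nM in this assay, at which 1 of the 4 values shown sits.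

On these data alone, it remains open whether a methoxymethyl group, a carboxylic acid or an aminomethyl group in place of the hydroxymethyl group would stay with compound 1 at the limit or join compounds 2, 3 and 4. Also open, as far as these compounds go, is whether a 3-(hydroxymethyl)phenyl group would do the same as the 4-(hydroxymethyl)phenyl group, which would show whether the hydroxymethyl group separates compound 1 wherever it sits on that ring.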